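Methoxy ring exchange from compound 3 to compound 4

The source may report more compounds than this note shows. Statements on the series, on what has been measured and on what is new or still open speak of the compounds shown alone.

Measured in an ADME assay on the whole organism (Rattus norvegicus) for metabolic stability, at a dose of 0.5 mg/kg by the intravenous route; on this read-out higher numbers stand for a longer-lived compound and lower numbers for a shorter-lived compound:
Compound 1 `COc1cc(OCc2csc(-c3ccc(C(F)(F)F)cc3)n2)c2cc(-c3cn4nc(OC)sc4n3)oc2c1`: 31 h
Compound 2 `COc1cc(OCc2cccc(-c3ccc(OC)nc3)c2)c2cc(-c3cn4nc(OC)sc4n3)oc2c1`: 45 h
Compound 3 `COc1cc(OCc2cccc(-c3cnc(OC)nc3)c2)c2cc(-c3cn4nc(OC)sc4n3)oc2c1`: 40 h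

Compound 3 stands within the scatter of both other compounds on these numbers. Compound 4 `COc1cc(OCc2cccc(-c3cnc(OC)cn3)c2)c2cc(-c3cn4nc(OC)sc4n3)oc2c1` has the same atoms joined differently: 5-methoxypyrazin-2-yl in place of 2-methoxypyrimidin-5-yl on an aromatic carbon. In words, 5-methoxypyrazin-2-yl takes the place of 2-methoxypyrimidin-5-yl on an aromatic carbon, meta to a large group. Among the compounds with values here, one measured step bears on this change, at the same place: a 1.1-fold lower number from compound 2 to compound 3 (0.05 log units; within the scatter). On that basis, no step beyond the scatter is expected in this assay, and no direction can be called. The expected step is a 1.1-fold lower number from compound 3 to compound 4 (0.02 log units; within the scatter). For compound 4 the estimated value is 38 h, with an expected range of 22 h to 62 h.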

Compound 4, half-life: 61 h
Compound 4: middle estimate off by 1.6-fold (0.21 log units), on the low side; the measured number falls inside the stated range.
By their numbers in this assay, from the lowest: compounds 1, 3, 2 and 4 (each within the scatter of the next).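

In this assay the exchange of 2-methoxypyrimidin-5-yl for 5-methoxypyrazin-2-yl gives a 1.5-fold higher number from compound 3 to compound 4 (0.18 log units; within the scatter) and the exchange of 6-methoxypyridin-3-yl for 5-methoxypyrazin-2-yl gives a 1.4-fold higher number from compound 2 to compound 4 (0.13 log units; within the scatter) at the same place. This place, on an aromatic carbon meta to a large group, now carries three methoxy-bearing six-membered aromatic rings whose numbers all lie within the scatter of one another, including the two rings with the same atoms joined differently. Open, on these data alone, is whether an amine or a carboxylic acid in place of the methoxy group on this ring would hold the half-life within that scatter. No evidence bears on what lies behind these numbers.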